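Removing bromo from the fused ring of the shared core

The source may hold more compounds than are shown below. What is called first, only, known or untested is meant among the compounds shown, and "the series" means these compounds.

In a functional assay on the whole organism (strain albino) with Rattus norvegicus as the target, in the maximal electroshock model, with a stated time of 1 h, at a dose of 30 mg/kg by the intraperitoneal route (a lower number here means less inhibition, a higher number more inhibition at the dose given (going by the name of the read-out)), compound 1 `Cc1nc2ccccc2c(=O)n1NCc1nnc(/N=C/c2ccc(N(C)C)cc2)s1` gives 50%. Compound 2 `COc1ccc(/C=N/c2nnc(CNn3c(C)nc4ccc(Br)cc4c3=O)s2)cc1` gives 50% in this assay, level with compound 1 within the scatter. Compound 3 `COc1ccc(/C=N/c2nnc(CNn3c(C)nc4ccccc4c3=O)s2)cc1` differs from compound 2 by one change: hydrogen in place of bromo on an aromatic carbon. Within the data shown here, no measured pair differs in a single place, so the step has no direct precedent. Compound 1 also carries no bromo on its core and gives 50%, which supports an expectation of no step beyond the scatter, no change at the digits printed from compound 2 to compound 3 (within the scatter). Compound 3 is therefore estimated at 50%, with a range from 30% to 70%.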

Compound 3, a percentage reported as inhibition, in the whole organism at one dose (the size of the read-out at that dose, not a potency): 50%
Compound 3: the middle estimate sits on the measured number at the digits printed, and the stated range covers the measured number.
By their numbers in this assay, from the lowest: compounds 1, 2 and 3 (each within the scatter of the next).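

In this assay, among these compounds, hydrogen in place of bromo on an aromatic carbon of the fused system gives no change at the digits printed from compound 2 to compound 3 (within the scatter) as the first reading of this position from a pair differing in one place. Methoxy in place of dimethylamino on an aromatic carbon gives no change at the digits printed from compound 1 to compound 3 (within the scatter) and so adds a second single-place pair, at the other end of the molecule. On these data alone, whether a fluoro, an amine or a carboxylic acid at the bromo position would hold the read-out remains open. No supporting data bear on why these compounds read alike.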